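Enamide chain and indole fluoro in an antiproliferative series

A few compounds are considered here, and "the series" means these few. Any claim that something is new, unique, unknown or untested is made for them only; others in the source may bear on it.

Compound 1 `COc1cc(N(C)CCN(C)C)c(NC(=O)/C=C\C(C)C)cc1Nc1nc(C)cc(-c2cn(C)c3ccccc23)n1` and compound 3 `COc1cc(N(C)CCN(C)C)c(NC(=O)/C=C\C(C)C)cc1Nc1nc(C)cc(-c2cn(C)c3ccc(F)cc23)n1` share a core that differs only by fluoro in place of hydrogen on an aromatic carbon. In a functional assay on NCI-H1975 cells (Homo sapiens) for antiproliferative activity, read by MTT assay, with a stated time of 72 h (on this read-out lower numbers stand for stronger inhibition and higher numbers for weaker inhibition), compound 1 gives 1230 nM and compound 3 gives 8520 nM, a step of a 6.9-fold higher number from compound 1 to compound 3 (0.84 log units; beyond the scatter). Compound 2 `CCC/C=C\C(=O)Nc1cc(Nc2nc(C)cc(-c3cn(C)c4ccccc34)n2)c(OC)cc1N(C)CCN(C)C` carries propyl in place of isopropyl on a double-bonded chain carbon bound to a double-bonded chain carbon relative to compound 1, and in this assay compound 2 gives 254 nM; the step is a 4.8-fold lower number from compound 1 to compound 2 (0.69 log units; beyond the scatter). Compound 4 `CCC/C=C\C(=O)Nc1cc(Nc2nc(C)cc(-c3cn(C)c4ccc(F)cc34)n2)c(OC)cc1N(C)CCN(C)C` is not yet measured; it stands to compound 3 as compound 2 stands to compound 1, through (propyl in place of isopropyl on a double-bonded chain carbon bound to a double-bonded chain carbon), the same change at the same place. Among the measured compounds shown here, only this one earlier instance of the change is available, so the expected step in this assay is taken to match it: a 4.7-fold lower number from compound 3 to compound 4 (0.68 log units; beyond the scatter). On that basis compound 4 is expected to give about 1800 nM, with 700 nM to 4500 nM as the expected range.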

Compound 4, half-maximal inhibitory concentration: 12200 nM
Estimate against measurement, compound 4: 6.8-fold (0.83 log units) below; measured number outside the range, above it.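

In this assay, the propyl change gives a 1.4-fold higher number from compound 3 to compound 4 (0.16 log units; within the scatter), so the gain seen on the core of compound 1 does not carry over to the fluoro-bearing core: the same change on two cores in this assay, a 4.8-fold lower number (0.69 log units; beyond the scatter) from compound 1 to compound 2 and a 1.4-fold higher number (0.16 log units; within the scatter) from compound 3 to compound 4, 6.9-fold (0.84 log units) apart, beyond the scatter of two such steps

The fluoro change also weakens inhibition more on the propyl chain, with a 48-fold higher number from compound 2 to compound 4 (1.68 log units; beyond the scatter), than on the isopropyl chain: the same change on two cores in this assay, a 6.9-fold higher number (0.84 log units; beyond the scatter) from compound 1 to compound 3 and a 48-fold higher number (1.68 log units; beyond the scatter) from compound 2 to compound 4, 6.9-fold (0.84 log units) apart, beyond the scatter of two such steps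

Among the compounds shown here, the two changes are therefore not additive across these four compounds, but a single pair per core shows only that each step depends on the other group, not why it does or whether this extends beyond these compounds.

Going by these compounds, it remains open whether a longer chain such as butyl would follow propyl on each core. On these data alone, it is equally open whether chloro or methoxy in place of fluoro would produce the same weakening.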